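This account rests on a few compounds, and the source may have more. Where it says the series, first, only, none or still open, it means among the compounds named here.

Among the compounds with values here, in a functional assay on U-937 cells (Homo sapiens) for inhibition, read by MTT assay, with a stated time of 24 h (a lower number here means a stronger inhibitor of growth, a higher number a weaker inhibitor of growth), compound 2 `COc1ccc(Cn2ncc3c2NC(=O)CC(c2cccc(NC(=O)Nc4ccc(Cl)cc4)c2)=N3)cc1` gives 580 nM, the lower of the only two exact numbers available. Compound 1 `O=C1CC(c2ccc(NC(=O)Nc3ccc(Cl)c(C(F)(F)F)c3)cc2)=Nc2cnn(Cc3ccccc3)c2N1` gives 8680 nM, which is higher by more than the scatter. Compound 3 `O=C1CC(c2cccc(NC(=O)Nc3ccc(Cl)cc3)c2)=Nc2cn[nH]c2N1` reaches only a limit of the assay, > 30000 nM.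

Compound 4 `COc1ccc(Cn2ncc3c2NC(=O)CC(c2cccc(NC(=O)Nc4cccc(C(F)(F)F)c4)c2)=N3)cc1` keeps most of compound 2 but has 3-(trifluoromethyl)phenyl in place of 4-chlorophenyl on an amide-type nitrogen.

Within the data shown here, the one measured step, an at least 51-fold higher number from compound 2 to compound 3 (1.71 log units; beyond the scatter), is large, but it puts hydrogen in place of 4-methoxybenzyl on an aromatic nitrogen. Among the measured compounds shown here, that is a different place, so it gives no direct guide to this swap, and no measured step covers the amide-type nitrogen. The expectation therefore stays close to compound 2 at 580 nM, with no shift beyond the scatter in this assay and only a slight lean towards a higher number. The expected change is a 1.4-fold higher number from compound 2 to compound 4 (0.14 log units; within the scatter). For compound 4 the estimated value is 800 nM, with an expected range from 250 nM to 3000 nM.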

Compound 4, concentration for 50% growth inhibition: 280 nM
Estimate against measurement, compound 4: 2.9-fold (0.46 log units) above; low and high end bracket the measured number.
By their numbers in this assay, from the lowest: compound 4; then compound 2; then compound 1. At a limit, above all of these: compound 3.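

Within the data shown here, the new result is the first measured step at the amide-type nitrogen: in this assay, 3-(trifluoromethyl)phenyl in place of 4-chlorophenyl brings a 2.1-fold lower number from compound 2 to compound 4 (0.32 log units; beyond the scatter), a modest change. This position therefore accepts a group of 10 heavy atoms in place of one of 7, and growth inhibition is kept rather than lost. Nothing measured among the compounds shown accounts for the direction of this step.

Among these compounds, with only this one swap, it stays open whether the difference comes from the trifluoromethyl group itself or from its place on the ring, since the chlorine leaves and the new group enters together. Also open, as far as these compounds go, is how a phenyl ring carrying a carboxylic acid, or a cyclohexyl ring, would behave on this nitrogen.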